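Oxadiazole arm variation in a benzenesulfonamide series

The source may report more compounds than this note shows. Statements on the series, on what has been measured and on what is new or still open speak of the compounds shown alone.

Compound 3 `NS(=O)(=O)c1cc(-c2nnc(Cn3cc(-c4ccccc4)nn3)o2)c(Cl)cc1SCc1ccccc1` gives 170000 nM in a functional assay on MCF7 cells (Homo sapiens) for cytotoxicity, read by MTT assay, with a stated time of 72 h (on this read-out lower numbers stand for stronger inhibition and higher numbers for weaker inhibition), the highest of the three numbers recorded. Compound 2 `CC(C)(O)c1cn(Cc2nnc(-c3cc(S(N)(=O)=O)c(SCc4ccccc4)cc3Cl)o2)nn1` gives 168000 nM there, and a 1.0-fold higher number from compound 2 to compound 3 (0.01 log units; within the scatter), so the two cannot be ordered. Compound 1 `NC(=O)c1cn(Cc2nnc(-c3cc(S(N)(=O)=O)c(SCc4ccccc4)cc3Cl)o2)nn1` gives 78000 nM, and a 2.2-fold higher number from compound 1 to compound 3 (0.34 log units; beyond the scatter); likewise a 2.2-fold higher number from compound 1 to compound 2 (0.33 log units; beyond the scatter).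

Compound 4 `NS(=O)(=O)c1cc(-c2nnc(/C=C/c3ccccc3)o2)c(Cl)cc1SCc1ccccc1` is not yet measured. It differs from compound 3 in that (2-phenylethenyl in place of (4-phenyl-1H-1,2,3-triazol-1-yl)methyl on an aromatic carbon). Among the compounds with values here, none of the measured steps bears directly on this change: each of them exchanges only the group carried on the triazole ring (carbamoyl, 1-hydroxy-1-methylethyl, phenyl), and all of them leave the (4-phenyl-1H-1,2,3-triazol-1-yl)methyl arm itself in place. Those steps were modest at most, and the whole set sits in a narrow band of weak numbers. Removing the triazole and placing a 2-phenylethenyl group on the oxadiazole carbon is a larger alteration than any seen so far, so the direction is open; with no counter-evidence, a step within the scatter, or a small shift either way, is expected for a 1.1-fold lower number from compound 3 to compound 4 (0.05 log units; within the scatter). Compound 4 is therefore estimated at 150000 nM, with a range from 50000 nM to 400000 nM.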

Compound 4, half-maximal inhibitory concentration: 16000 nM
For compound 4 the middle estimate is 9.4-fold (0.97 log units) above the measured one; measured number below the stated range.
By their numbers in this assay, from the lowest: compound 4; then compound 1; then compounds 2 and 3 (each within the scatter of the next).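

In this assay, exchanging the whole arm at this aromatic carbon shifts the number much further than any exchange of the group carried on the triazole ring (an 11-fold lower number from compound 3 to compound 4 (1.03 log units; beyond the scatter); an 11-fold lower number from compound 2 to compound 4 (1.02 log units; beyond the scatter)), while the step from the carbamoyl member is smaller but still beyond the scatter (a 4.9-fold lower number from compound 1 to compound 4 (0.69 log units; beyond the scatter)). The change replaces (4-phenyl-1H-1,2,3-triazol-1-yl)methyl, with 12 heavy atoms and 3 hydrogen-bond acceptors, by 2-phenylethenyl, with 8 heavy atoms, 0 hydrogen-bond acceptors and 1 double bond outside aromatic rings, and compound 4 alone leaves the narrow band of weak numbers, holding the lowest number of the four. No measurement at hand explains the size of this step.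

The triazole ring, its linking carbon and the double bond all change together here, so these compounds cannot show which of them accounts for the step. Also open, going by these compounds, is whether the lower number survives with a saturated 2-phenylethyl chain in place of 2-phenylethenyl, or with an amine or a carboxylic acid on the phenyl ring of the 2-phenylethenyl group.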